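Ester change on the chloro compound: working notes

The compounds below may be only part of what the source reports. "The series", "measured", "known", "first", "only" and "open" are said of these compounds alone.

Measured so far in a physicochemical assay for metabolic stability, read by LC-MS, in phosphate buffer, with a stated time of 120 min, at pH 7.4, tested at 1 uM; on this read-out lower numbers stand for a less stable compound and higher numbers for a more stable compound:

- compound 1 `CC#CCn1c(N2CCC[C@@H](N)C2)nc2c1c(=O)n(Cc1ccc(Br)cc1C(=O)OC)c(=O)n2C` gives 99.4%
- compound 2 `CC#CCn1c(N2CCC[C@@H](N)C2)nc2c1c(=O)n(Cc1ccc(Br)cc1C(=O)OCC)c(=O)n2C` gives 98.4%
- compound 3 `CC#CCn1c(N2CCC[C@@H](N)C2)nc2c1c(=O)n(Cc1ccc(Cl)cc1C(=O)OCC)c(=O)n2C` gives 99.5%

Compound 3 stands at 99.5% and lies within the scatter of the other two, as a number 0.1 percentage points higher from compound 1 to compound 3 (within the scatter) and a number 1.1 percentage points higher from compound 2 to compound 3 (within the scatter) show.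

The next compound is compound 4 `CC#CCn1c(N2CCC[C@@H](N)C2)nc2c1c(=O)n(Cc1ccc(Cl)cc1C(=O)OC)c(=O)n2C`. The change is hydrogen in place of methyl on a saturated chain carbon bound to an oxygen next to a carbonyl group and reads ethoxycarbonyl to methoxycarbonyl. For the measured compounds named here, one measured step bears on it directly: the same exchange in the opposite direction, methyl in place of hydrogen, on the bromo compounds, a number 1 percentage points lower from compound 1 to compound 2 (within the scatter). Chloro in place of bromo, a number 1.1 percentage points higher from compound 2 to compound 3 (within the scatter), shows no step beyond the scatter either, so the bromo result is expected to carry over. No step beyond the scatter is therefore expected in this assay, and the data give no direction. The expected size is a number 0.5 percentage points lower from compound 3 to compound 4 (within the scatter) and no more than that. For compound 4 the estimated value is 99% with an expected range from 96% to 101%.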

Compound 4, percent of the compound remaining: 101%
The estimate for compound 4 lay 2 percentage points below the measured number; the measured number falls inside the stated range.
By their numbers in this assay, from the lowest: compounds 2, 1, 3 and 4 (each within the scatter of the next).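

In this assay, ethoxycarbonyl to methoxycarbonyl on the chloro compounds gives a number 1.5 percentage points higher from compound 3 to compound 4 (within the scatter), and chloro in place of bromo on the methoxycarbonyl compounds gives a number 1.6 percentage points higher from compound 1 to compound 4 (within the scatter), so each exchange now stays within the scatter on a second partner, not only on the one seen before. Exchanging both together gives a number 2.6 percentage points higher from compound 2 to compound 4 (within the scatter), so the combined change also stays within the scatter, and no two of the four compounds are separated in this read-out. No measurement on hand explains why these compounds read alike.

Going by these compounds, whether a carboxylic acid, a primary amide or a longer chain such as propoxycarbonyl in this place would stay within the scatter remains open. The four compounds contain no step beyond the scatter, so they do not show which groups at this position, if any, change the read-out.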